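Fluoro in place of methoxy at the assay limit

The source may hold more compounds than are shown below. What is called first, only, known or untested is meant among the compounds shown, and "the series" means these compounds.

In a functional assay on HCT-116 cells (Homo sapiens) for inhibition, read by MTT assay, with a stated time of 48 h (a lower number here means a stronger inhibitor, a higher number a weaker inhibitor), compound 1 (`COc1cc(-c2nnc(SCc3ccc(C)cc3)n2-c2ccc(N(C)C)cc2)cc(OC)c1OC`) gives > 60000 nM, which is a limit. Compound 2 (`COc1ccc(C(=O)CSc2nnc(-c3cc(OC)c(OC)c(OC)c3)n2-c2ccc(N(C)C)cc2)cc1`) gives > 60000 nM, also a limit, so its standing has no number behind it. Compound 3 (`COc1cc(-c2nnc(SCC(=O)c3ccc(F)cc3)n2-c2ccc(N(C)C)cc2)cc(OC)c1OC`) carries fluoro in place of methoxy on an aromatic carbon, para to a large group: fluoro in place of methoxy on an aromatic carbon. Going by the values given here, the one measured step, a step that the two limits leave unreadable from compound 1 to compound 2, offers no size, and the series so far offers only (the limit of > 60000 nM in this assay, at which 2 of the 2 values shown sit). No step beyond the scatter can therefore be expected in this assay, and no direction can be read. The estimated change is an at least 1.2-fold lower number from compound 2 to compound 3 (0.07 log units; that floor lies within the scatter). For compound 3 the expected value is 50000 nM, with an estimated range of 15000 nM to 100000 nM.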

Compound 3, half-maximal inhibitory concentration: 31100 nM
The estimate for compound 3 lay 1.6-fold (0.21 log units) above the measured number, and the stated range covers the measured number.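

In this assay, going by these compounds alone, compound 3 is the first to give a number rather than a limit, and fluoro in place of methoxy on an aromatic carbon, para to a large group, gives an at least 1.9-fold lower number from compound 2 to compound 3 (0.28 log units; that floor lies within the scatter). The change of the whole group gives an at least 1.9-fold lower number from compound 1 to compound 3 (0.28 log units; that floor lies within the scatter); both steps are floors, so their true sizes are not fixed. The other compounds supply no number: the limit of > 60000 nM in this assay, at which 2 of the 3 values shown sit.

The step between the two limit compounds cannot be read. On these data alone, whether an amine or a carboxylic acid in place of fluoro on that aromatic carbon would give a lower number stays open.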